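Swapping propylamino for butylsulfanyl on a shared core

The compounds below may be only part of what the source reports. "The series", "measured", "known", "first", "only" and "open" are said of these compounds alone.

Measured compounds in a functional assay (spleen, spleen) for activation, with Mus musculus as the target; on this read-out higher numbers stand for an effect only at larger amounts of compound and lower numbers for an effect already at smaller amounts:
compound 1, `COc1ccc(Cn2c(O)nc3c(N)ncnc32)cc1`: 10 uM
compound 2, `CCCNc1nc(N)c2nc(O)n(Cc3ccccc3)c2n1`: 0.1 uM
compound 3, `COc1nc2c(N)ncnc2n1Cc1ccccc1`: > 10 uM

Three compounds share a core and differ in the groups attached to it. In this assay compound 2 gives 0.1 uM, the lowest of the two numbers recorded. The nearest number belongs to compound 1, which gives 10 uM, a gap that lies beyond the usual scatter. For compound 3 the result is a limit of the assay, > 10 uM, and not a number; this is the limit of > 10 uM in this assay, at which 1 of the 3 values shown sits.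

The next compound, compound 4 with the structure `CCCCSc1nc(N)c2nc(O)n(Cc3ccccc3)c2n1`, has not yet been measured. It differs from compound 2 in one place: butylsulfanyl in place of propylamino on an aromatic carbon. Going by the values given here, no step of this kind has been measured in the set, so its size can only be guessed. The chain stays similar in length, but the hydrogen-bond donor leaves. A modest loss in this assay is expected, with a step of a 3.0-fold higher number from compound 2 to compound 4 (0.48 log units; beyond the scatter) in the direction of a higher number, though it could fall within the scatter. Compound 4 is therefore estimated at 0.3 uM, in a range from 0.05 uM to 3 uM.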

Compound 4, minimum effective concentration: 0.01 uM
For compound 4 the middle estimate is 30-fold (1.48 log units) above the measured one; measured number outside the range, below it.
By their numbers in this assay, from the lowest: compound 4; then compound 2; then compound 1.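

In this assay, the aromatic carbon between two ring nitrogen atoms accepts butylsulfanyl in place of propylamino, and the number improves rather than worsens, with a 10-fold lower number from compound 2 to compound 4 (1.00 log units; beyond the scatter). The group that leaves carries a hydrogen-bond donor and the group that enters carries none, so in this pair a donor at this position is not needed for an effect at small amounts of compound. The earlier compounds could not show this, as no two of them differed in only one place, and nothing measured here explains why the number falls.

This step changes two things at once, the linking atom and the chain, with 5 heavy atoms entering and 4 leaving, so the shift cannot yet be assigned to either: butylamino, which keeps the chain and restores the nitrogen link, and propylsulfanyl, which keeps the sulfur link with the shorter chain, would separate the two. Also open, from the compounds shown here alone, is whether a longer chain such as pentylsulfanyl, or an oxygen-linked group such as butoxy, would give a number lower still or a higher one.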